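Methyl on the Amide Nitrogen of Compound 2

The source may report more compounds than this note shows. Statements on the series, on what has been measured and on what is new or still open speak of the compounds shown alone.

Measured compounds in a functional assay on the whole organism with Rattus norvegicus as the target, at a dose of 20 mg/kg by the oral route; on this read-out lower numbers stand for less inhibition and higher numbers for more inhibition at the one dose given (going by the name of the read-out):
- compound 1, `NC(=O)/C=C1\CCc2cc(Cl)ccc21`, with compound 1 giving 30%
- compound 2, `CCNC(=O)/C=C1\CCc2ccc(F)cc21`, with compound 2 giving 45%
- compound 3, `CNC(=O)/C=C1\CCc2cc(Cl)ccc21`, with compound 3 giving 40%

Compound 2 gives a number that is beyond the scatter away from compound 1, while the numbers of compound 2 and compound 3 lie within the scatter of each other, so no order between these two can be read. Compound 4, `CCN(C)C(=O)/C=C1\CCc2ccc(F)cc21`, has not been measured. It differs from compound 2 by methyl in place of hydrogen on an amide-type nitrogen. Among the measured compounds shown here, one measured step bears on this change: a number 10 percentage points higher from compound 1 to compound 3 (within the scatter). That step also puts a methyl in place of hydrogen on an amide-type nitrogen, though there the nitrogen starts with two hydrogens rather than one, and the core carries chlorine rather than fluorine. Since that step stayed within the scatter, the account expects no step beyond the scatter for compound 4 in this assay either, with a direction that cannot be told. The expected step is a number 3 percentage points higher from compound 2 to compound 4 (within the scatter). Compound 4 is therefore estimated at 48%, with a range from 30% to 65%.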

Compound 4, a percentage reported as inhibition, in the whole organism at one dose (the size of the read-out at that dose, not a potency): 20%
Compound 4: the middle estimate sits 28 percentage points above what was measured; the whole stated range lies above it.
By their numbers in this assay, from the lowest: compounds 4, 1, 3 and 2 (each within the scatter of the next, the first and the last beyond it).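

In this assay, among the compounds shown here, methyl in place of hydrogen on an amide-type nitrogen now gives a step beyond the scatter, which the earlier compounds did not show: a number 25 percentage points lower from compound 2 to compound 4 (beyond the scatter). Here the nitrogen already carries a saturated chain carbon, and the change from ethylamino to ethyl(methyl)amino leaves it with no amide hydrogen, so this position proves sensitive to the change on this core. The same replacement therefore cannot be carried from one core to the other in this assay, since the two steps differ by more than the scatter allows: the same change on two cores in this assay, a number 10 percentage points higher (within the scatter) from compound 1 to compound 3 and a number 25 percentage points lower (beyond the scatter) from compound 2 to compound 4, 35 percentage points apart, beyond the scatter of two such steps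

The two steps differ both in what the nitrogen starts with and in whether the core carries chlorine or fluorine, so the compounds shown cannot tell which of these accounts for the gap. They also leave open how a propyl group in place of the methyl on that nitrogen, or a pyrrolidine ring closed through the nitrogen, would read on the fluorine core.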